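The source may report more compounds than this note shows. Statements on the series, on what has been measured and on what is new or still open speak of the compounds shown alone.

The measured compounds:

compound 1, `CCCCCCCCNC1=CC(=O)C(C(C)(C)C)=CC1=O`: 70000 nM
compound 2, `CCCCCCCCNC1=CC(=O)C=C(C(C)(C)C)C1=O`: 20000 nM
compound 3, `CCCCNC1=CC(=O)C(C[C@]2(C)[C@@H](C)CC[C@]3(C)C(C)=CCC[C@@H]23)=CC1=O`: > 100000 nM

In a functional assay on NCI-H460 cells (Homo sapiens) for cytotoxicity, read by MTT assay, with a stated time of 72 h (on this read-out higher numbers stand for weaker inhibition and lower numbers for stronger inhibition), compound 1 gives 70000 nM and compound 2 gives 20000 nM. For compound 3 the result in this assay is only a limit of the assay, > 100000 nM, as noted in the limit of > 100000 nM in this assay, at which 1 of the 3 values shown sits; no number is known for it. Compound 4, `CC1=CCC[C@H]2[C@](C)(CC3=CC(=O)C=CC3=O)[C@@H](C)CC[C@]12C`, is not yet measured in this assay and differs from compound 3 by hydrogen in place of butylamino on a double-bonded ring carbon. Among the compounds with values here, with compound 3 sitting at a limit, no step between these two compounds can be computed. The step of a number no higher from compound 3 to compound 4 (the limit leaves the size open) is expected to be small, not beyond the usual scatter, in either direction. Compound 4 is expected at 100000 nM, between 30000 nM and 300000 nM.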

Compound 4, half-maximal inhibitory concentration: 84000 nM
For compound 4 the middle estimate is 1.2-fold (0.08 log units) above the measured one, within the range that was stated.
By their numbers in this assay, from the lowest: compound 2; then compounds 1 and 4 (each within the scatter of the next). At a limit, above all of these: compound 3.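

With hydrogen in place of butylamino on the double-bonded ring carbon, this assay shows an at least 1.1-fold lower number from compound 3 to compound 4 (0.07 log units; that floor lies within the scatter). Compound 3 gives > 100000 nM, which is a limit of the assay and not a number. The true size of this step cannot be read because compound 3 sits at that limit: the limit of > 100000 nM in this assay, at which 1 of the 4 values shown sits.

The compounds shown leave open how a methoxy group, a carboxylic acid or a longer amine chain would read at this ring carbon on the core of compound 4. They also leave open whether hydrogen in place of the amine chain would read the same way on the core of compound 1.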